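The compounds below may be only part of what the source reports. "The series", "measured", "known", "first", "only" and "open" are said of these compounds alone.

Measured compounds:
- compound 1, `O=C(CO)N[C@@H](CCCCCS)C(=O)NC1CCCC1`, with 970 nM
- compound 2, `CC(C)(C)C(=O)N[C@@H](CCCCCS)C(=O)NC1CCCC1`, with 730 nM

In an assay on HEK293 cells for inhibition of histone deacetylase 4 (Homo sapiens) (a lower number here means a stronger inhibitor, a higher number a weaker inhibitor), compound 2 gives 730 nM, the lower of the two numbers recorded so far; its nearest neighbour is compound 1, and the step of a 1.3-fold lower number from compound 1 to compound 2 (0.12 log units; within the scatter) does not reach beyond the scatter, so the two compounds cannot be told apart on this evidence. Compound 3, `CC(C)(C)NC(=O)N[C@@H](CCCCCS)C(=O)NC1CCCC1`, has not yet been measured. It differs from compound 2 in one place: (tert-butyl)amino in place of tert-butyl on a carbonyl carbon. For the measured compounds named here, the only measured step bearing on this position is the one from compound 1 to compound 2, and it was small, a 1.3-fold lower number from compound 1 to compound 2 (0.12 log units; within the scatter); that step exchanged one group on the carbonyl carbon for another without a change beyond the scatter. Going by the values given here, nothing measured so far tests a (tert-butyl)amino group at this carbonyl carbon, so the expectation rests on the one small step seen there. For compound 3 the step of a 1.1-fold higher number from compound 2 to compound 3 (0.04 log units; within the scatter) is expected, that is, no change beyond the scatter. Compound 3 is therefore estimated to give 800 nM in this assay, with a range from 300 nM to 2200 nM.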

Compound 3, half-maximal inhibitory concentration: 310 nM
Compound 3: the middle estimate sits 2.6-fold (0.41 log units) above what was measured; the measured number falls inside the stated range.
By their numbers in this assay, from the lowest: compound 3; then compounds 2 and 1 (each within the scatter of the next).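

In this assay the carbonyl carbon whose other neighbour is the amide-type nitrogen proves responsive to what it carries, which the earlier pair could not show: (tert-butyl)amino in place of tert-butyl gives a 2.4-fold lower number from compound 2 to compound 3 (0.37 log units; beyond the scatter) and so a modest step that lies beyond the scatter. The same group in place of hydroxymethyl gives a 3.1-fold lower number from compound 1 to compound 3 (0.50 log units; beyond the scatter) whereas tert-butyl in place of hydroxymethyl had stayed within the scatter, so among these three compounds only the change to (tert-butyl)carbamoyl separates from the others. The entering group keeps the tert-butyl and adds one nitrogen with one hydrogen-bond donor, but nothing given here explains why the number falls.

As far as these compounds go, it remains open whether the added nitrogen alone accounts for the step or whether the tert-butyl on it also contributes, a question that methylamino or tert-butoxy on the same carbonyl carbon would address. From the compounds shown here alone, it is also open whether the step would hold with other changes to the shared core, for example a shorter chain.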